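The source may report more compounds than this note shows. Statements on the series, on what has been measured and on what is new or still open speak of the compounds shown alone.

Of the compounds shown here, three that share one core have been measured in a functional assay on KB cells (Homo sapiens) for cytotoxicity, read by resazurin assay, with a stated time of 3 days; a higher number here means a weaker inhibitor, a lower number a stronger inhibitor. Compound 1 `CCCCCCCCC(=O)NCC(C)(C)CC1=C(O)C(=O)c2ccccc2C1=O` gives 19700 nM in this assay. Compound 2 `CCCCCCCCCC(=O)NCC(C)(C)CC1=C(O)C(=O)c2ccccc2C1=O` gives 18500 nM in this assay. The change between them, (methyl in place of hydrogen on a saturated chain carbon, eight bonds along the chain from a carbonyl carbon), made a 1.1-fold lower number from compound 1 to compound 2 (0.03 log units; within the scatter). Compound 3 `CCCCCCC(=O)OCC(C)(C)CC1=C(O)C(=O)c2ccccc2C1=O` gives 14400 nM in this assay; how the core of compound 3 differs from the core of compound 1 is not broken down here, and its number sits within the scatter of both compound 1 and compound 2.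

Compound 4 `CCCCCCCC(=O)OCC(C)(C)CC1=C(O)C(=O)c2ccccc2C1=O` has not yet been measured. It differs from compound 3 by methyl in place of hydrogen on a saturated chain carbon, six bonds along the chain from a carbonyl carbon. Going by the values given here, this is the same kind of change as the one made from compound 1 to compound 2, not the same one: there the place was eight bonds along the chain from a carbonyl carbon, here it is six bonds along the chain from a carbonyl carbon. Because the earlier step of a 1.1-fold lower number from compound 1 to compound 2 (0.03 log units; within the scatter) stayed within the scatter, a step of about a 1.1-fold lower number from compound 3 to compound 4 (0.04 log units; within the scatter) is expected this time as well. Compound 4 is therefore estimated to give 13000 nM in this assay, most likely between 7000 nM and 25000 nM.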

Compound 4, half-maximal inhibitory concentration: 38300 nM
For compound 4 the middle estimate is 2.9-fold (0.47 log units) below the measured one; measured number outside the range, above it.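

In this assay, adding one methyl to the chain of compound 3 made a measurable difference, giving a 2.7-fold higher number from compound 3 to compound 4 (0.42 log units; beyond the scatter), so this compound became a weaker inhibitor. Set beside the earlier step, the same kind of change did not behave alike on the two cores: the same change on two cores in this assay, a 1.1-fold lower number (0.03 log units; within the scatter) from compound 1 to compound 2 and a 2.7-fold higher number (0.42 log units; beyond the scatter) from compound 3 to compound 4, 2.8-fold (0.45 log units) apart, beyond the scatter of two such steps. This shows that a step that stays within the scatter on one core cannot simply be assumed to do so on another in this series, but it does not show why: the two steps differ both in the core and in the place of the methyl, eight bonds along the chain from a carbonyl carbon in one and six in the other, and a single pair on each core cannot separate the two.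

The compounds shown leave open whether a longer chain on the core of compound 3 would continue this rise or reverse it. They also leave open how an amine or a carboxylic acid at the end of the chain would compare.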